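A Carboxy Azetidine Replaces a Hydroxyethyl Amine

This account rests on a few compounds, and the source may have more. Where it says the series, first, only, none or still open, it means among the compounds named here.

In a functional assay on B16-F10 cells (Mus musculus) for antiproliferative activity, read by CCK-8 assay, with a stated time of 48 h (a higher number here means a weaker inhibitor, a lower number a stronger inhibitor), compound 1 `COc1ccc(/C=C\c2cc(OC)c(OC)c(OC)c2)cc1OCc1ccc(CN[C@H](C(=O)O)[C@H](C)O)cc1` gives > 10000 nM, which is a limit of the assay and not a number. Going by the values given here, compound 2 `COc1ccc(/C=C\c2cc(OC)c(OC)c(OC)c2)cc1OCc1ccc(CNCCO)cc1` gives 6600 nM, the only true number so far. On a saturated chain carbon bound to an aromatic carbon, compound 3 `COc1ccc(/C=C\c2cc(OC)c(OC)c(OC)c2)cc1OCc1ccc(CN2CC(C(=O)O)C2)cc1` carries 3-carboxyazetidin-1-yl in place of (2-hydroxyethyl)amino (3-carboxyazetidin-1-yl in place of (2-hydroxyethyl)amino on a saturated chain carbon bound to an aromatic carbon).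

Among the compounds with values here, one measured step bears on this change, an at least 1.5-fold lower number from compound 1 to compound 2 (0.18 log units; that floor lies within the scatter), and it is only a floor that stays within the scatter. Within the data shown here, it does show that the series' one carboxy-bearing compound measured so far gave no number, and compound 3 also carries a carboxy group. Among the measured compounds shown here, no measurement yet covers the four-membered ring itself. The evidence therefore points only weakly toward a higher number in this assay, and a report of a limit would be no surprise. The expected change is a 1.8-fold higher number from compound 2 to compound 3 (0.26 log units; within the scatter), a small move toward weaker inhibition. For compound 3 the estimated value is 12000 nM, with an expected range from 4500 nM to 30000 nM.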

Compound 3, half-maximal inhibitory concentration: > 10000 nM
Compound 3 ended at the assay's limit (the forecaster's own chance of this, stated with the estimate: 55%); the middle value lies beyond the limit too.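

In this assay, 3-carboxyazetidin-1-yl in place of (2-hydroxyethyl)amino on a saturated chain carbon bound to an aromatic carbon gives an at least 1.5-fold higher number from compound 2 to compound 3 (0.18 log units; that floor lies within the scatter), so this step fixes no size for the change and shows only its direction at the floor. New here is that a second carboxy-bearing compound, this time with the amine nitrogen inside a four-membered ring, also ends at a limit and not at a number, which leaves compound 2 as the only one of the three with a true value: the limit of > 10000 nM in this assay, at which 2 of the 3 values shown sit. The step between compound 1 and compound 3 cannot be read, as both values are limits.

The compounds shown leave open whether the limit goes with the carboxylic acid or with the four-membered ring, as the two enter together in compound 3. A 3-(hydroxymethyl)azetidin-1-yl group or a methyl ester in place of the carboxylic acid would bear on the first, and a carboxylic acid on a longer open chain would bear on the second.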